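Amine variation on the saturated chain, toward compound 4

The compounds below may be only part of what the source reports. "The series", "measured", "known", "first", "only" and "open" are said of these compounds alone.

The three measured compounds share one core and differ only in the amine borne on the saturated chain carbon. Compound 1 `CCN(CC)CCCOc1ccc2cc(NC(=O)c3ccc(O)c(CC=C(C)C)c3)c(=O)oc2c1C` carries a diethylamino group and gives 4900 nM in a functional assay on SK-BR-3 cells (Homo sapiens) for antiproliferative activity; on this read-out lower numbers stand for stronger inhibition and higher numbers for weaker inhibition. Compound 2 `CC(C)=CCc1cc(C(=O)Nc2cc3ccc(OCCCNCC(C)C)c(C)c3oc2=O)ccc1O`, with an isobutylamino group, gives 1030 nM in this assay; compound 3 `CC(C)=CCc1cc(C(=O)Nc2cc3ccc(OCCCN(C(C)C)C(C)C)c(C)c3oc2=O)ccc1O`, with a diisopropylamino group, gives 1600 nM. Compound 2 stands at the lowest number of the three, yet its gap to compound 3 is within the scatter: a 1.6-fold higher number from compound 2 to compound 3 (0.19 log units; within the scatter). Both moves away from the diethylamino group gave lower numbers, a 4.8-fold lower number from compound 1 to compound 2 (0.68 log units; beyond the scatter) and a 3.1-fold lower number from compound 1 to compound 3 (0.49 log units; beyond the scatter).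

Compound 4 `CC(C)=CCc1cc(C(=O)Nc2cc3ccc(OCCCNCc4ccccc4)c(C)c3oc2=O)ccc1O` is the next point: phenyl in place of isopropyl on a saturated chain carbon bound to an amine nitrogen. Among the compounds with values here, no measured step alters this part of the chain, so only the general bearing of the amine steps is available. They show that changing the amine moves the number modestly at most, and the step from compound 2 to compound 3 is within the scatter. For compound 4 in this assay the change is expected to give no step beyond the scatter, a 1.5-fold higher number from compound 2 to compound 4 (0.16 log units; within the scatter), with a wide margin to allow for the new ring. Compound 4 is estimated at 1500 nM, between 500 nM and 4500 nM.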

Compound 4, half-maximal inhibitory concentration: 470 nM
The estimate for compound 4 lay 3.2-fold (0.50 log units) above the measured number, and the stated range ends above it.
By their numbers in this assay, from the lowest: compound 4; then compounds 2 and 3 (each within the scatter of the next); then compound 1.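

Phenyl in place of isopropyl on a saturated chain carbon bound to an amine nitrogen gives the first step beyond the scatter among the amines that had already improved on diethylamino in this assay (a 2.2-fold lower number from compound 2 to compound 4 (0.34 log units; beyond the scatter)), whereas the earlier step between compound 2 and compound 3 stayed within the scatter. The benzylamino group also separates from the diisopropylamino group (a 3.4-fold lower number from compound 3 to compound 4 (0.53 log units; beyond the scatter)), and its step from the diethylamino group is the only one in this set graded large (a 10-fold lower number from compound 1 to compound 4 (1.02 log units; beyond the scatter)), so the amine position is shown to carry more than the modest steps seen before. Nothing available explains the lower number with the phenyl group, so the series records the difference without a cause.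

The compounds shown leave open whether the ring must be aromatic, a question that a cyclohexylmethylamino group at this position would address. Also open, from the compounds shown here alone, are the effect of a longer link between ring and amine nitrogen, as in a phenethylamino group, and of a methoxy or chloro group on the benzyl ring.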